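Ethylsulfanyl to trifluoromethoxy on the aryl nitrile arm

The compounds below may be only part of what the source reports. "The series", "measured", "known", "first", "only" and "open" are said of these compounds alone.

Compound 2 `CCSc1cc(C#N)cc(-c2ccc3ccc(C)nc3c2)c1` gives 72 nM in a functional assay on CHO cells for inhibition of metabotropic glutamate receptor 5 (Rattus norvegicus), read by FLIPR and calcium flux (on this read-out lower numbers stand for stronger inhibition and higher numbers for weaker inhibition), and so stands with the higher of the two numbers measured; compound 1 `Cc1ccc2ccc(-c3cc(F)cc(C#N)c3)cc2n1` gives 0.8 nM in this assay. Among the compounds with values here, the one measured step, a 90-fold higher number from compound 1 to compound 2 (1.95 log units; beyond the scatter), shows how much the number moved when ethylsulfanyl entered in place of fluoro. Compound 3 `Cc1ccc2ccc(-c3cc(C#N)cc(OC(F)(F)F)c3)cc2n1` carries trifluoromethoxy in place of ethylsulfanyl on an aromatic carbon. Within the data shown here, no pair measured here contains trifluoromethoxy, so the step bearing on it is only the fluoro-to-ethylsulfanyl change, and compound 3 sits between the two known points: it keeps a multi-atom substituent at that position, as compound 2 does, yet brings fluorine back, as in compound 1. Because of a 90-fold higher number from compound 1 to compound 2 (1.95 log units; beyond the scatter) and the ethylsulfanyl leaving in compound 3, the step of a 9.0-fold lower number from compound 2 to compound 3 (0.95 log units; beyond the scatter) is expected to lower the number, short of the value of compound 1. The estimate for compound 3 is 8 nM in this assay, within 1.5 nM to 40 nM.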

Compound 3, half-maximal inhibitory concentration: 75 nM
Estimate against measurement, compound 3: 9.4-fold (0.97 log units) below, outside the stated range (above it).
By their numbers in this assay, from the lowest: compound 1; then compounds 2 and 3 (each within the scatter of the next).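

In this assay, trifluoromethoxy in place of ethylsulfanyl gives a 1.0-fold higher number from compound 2 to compound 3 (0.02 log units; within the scatter) and so leaves these two groups indistinguishable at this position, meta to a cyano group, even though they share neither their heavy-atom count nor their heteroatoms. Trifluoromethoxy in place of fluoro gives a 94-fold higher number from compound 1 to compound 3 (1.97 log units; beyond the scatter) and stands close to a 90-fold higher number from compound 1 to compound 2 (1.95 log units; beyond the scatter) in size, so the higher number is not specific to ethylsulfanyl, and the fluorine atoms of trifluoromethoxy do not restore the number of compound 1. No measurement at hand explains this result.

Still open, as far as these compounds go, is whether any group other than fluoro can hold a number near that of compound 1 here, for instance chloro, methoxy or an amine. A methyl or a longer alkyl chain at this position would show whether the sulfur or oxygen link plays any part.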